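Carbamate chain variation on the shared core: compound 4

The compounds below may be only part of what the source reports. "The series", "measured", "known", "first", "only" and "open" are said of these compounds alone.

Measured so far:
compound 1 `CCCOC(=O)Nc1ccc(S(=O)(=O)N2C[C@H](c3ccccc3)NC2=O)cc1CC`: 60 nM
compound 2 `CCCCOC(=O)Nc1ccc(S(=O)(=O)N2C[C@H](c3ccccc3)NC2=O)cc1CC`: 200 nM
compound 3 `CCc1cc(S(=O)(=O)N2C[C@H](c3ccccc3)NC2=O)ccc1NC(=O)NC1CCCCC1`: 500 nM

In a functional assay on A549 cells (Homo sapiens) for cytotoxicity, read by MTT assay (on this read-out lower numbers stand for stronger inhibition and higher numbers for weaker inhibition), compound 1 gives 60 nM, the lowest of the three numbers; its nearest neighbour is compound 2 with 200 nM, and the furthest is compound 3 with 500 nM.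

Compound 4 `CCc1cc(S(=O)(=O)N2C[C@H](c3ccccc3)NC2=O)ccc1NC(=O)OC(C)C` differs from compound 1 in one place, (isopropyl in place of propyl on an oxygen next to a carbonyl group); the two have the same atoms, joined differently. Among the compounds with values here, two measured steps bear on this position. Lengthening the chain by methyl three bonds along from the oxygen gives a 3.3-fold higher number from compound 1 to compound 2 (0.52 log units; beyond the scatter), and exchanging propoxy for cyclohexylamino gives an 8.3-fold higher number from compound 1 to compound 3 (0.92 log units; beyond the scatter); the butoxy to cyclohexylamino step reads a 2.5-fold higher number from compound 2 to compound 3 (0.40 log units; beyond the scatter). Within the data shown here, no measured step keeps the count of the chain and changes only its shape, so the bearing of these steps is indirect. The expectation for compound 4 is therefore a step near or within the scatter, leaning toward a higher number, a 1.5-fold higher number from compound 1 to compound 4 (0.18 log units; within the scatter). Compound 4 is estimated at 90 nM, with a range from 40 nM to 250 nM.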

Compound 4, half-maximal inhibitory concentration: 60 nM
The estimate for compound 4 lay 1.5-fold (0.18 log units) above the measured number; the range from low to high includes it.
By their numbers in this assay, from the lowest: compounds 1 and 4 (each within the scatter of the next); then compound 2; then compound 3.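

In this assay, within the data shown here, isopropyl in place of propyl on an oxygen next to a carbonyl group gives no change at the digits printed from compound 1 to compound 4 (within the scatter); at this position, then, the shape of the chain can change at the same count without a step beyond the scatter, which the earlier compounds could not show. Branching also separates compound 4 from the other two changes, with a 3.3-fold lower number from compound 2 to compound 4 (0.52 log units; beyond the scatter) and an 8.3-fold lower number from compound 3 to compound 4 (0.92 log units; beyond the scatter), so among these compounds only butyl and cyclohexylamino go with higher numbers. The data at hand offer no explanation for the flat propyl to isopropyl step.

Open, going by these compounds, is whether a more branched tert-butyl or a cyclopropyl on the same oxygen stays within the scatter of compound 1. Also open, on these data alone, is how a shorter ethyl or a longer pentyl chain reads.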